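The source may report more compounds than this note shows. Statements on the series, on what has been measured and on what is new or still open speak of the compounds shown alone.

Compound 3 `Cc1cc(C#N)cc(C)c1Oc1ccnc(S(=O)(=O)CC(=O)Nc2ccc(Cl)cc2)n1` is one of three close analogues that share a core and differ only in the aryl group on the amide nitrogen. In an ADME assay on MT4 cells (Homo sapiens) for cytotoxicity, read by MTT assay, with a stated time of 4 days (on this read-out higher numbers stand for lower toxicity in this test and lower numbers for higher toxicity in this test), compound 3 gives 16600 nM, the lowest of the three numbers, though its distance to each of the other two lies within the scatter. Compound 1 `Cc1cc(C#N)cc(C)c1Oc1ccnc(S(=O)(=O)CC(=O)Nc2ccccc2)n1` gives 29300 nM in this assay, and compound 2 `Cc1cc(C#N)cc(C)c1Oc1ccnc(S(=O)(=O)CC(=O)Nc2cccc(Cl)c2)n1` gives 25400 nM. The three steps among them, a 1.2-fold lower number from compound 1 to compound 2 (0.06 log units; within the scatter), a 1.8-fold lower number from compound 1 to compound 3 (0.25 log units; within the scatter) and a 1.5-fold lower number from compound 2 to compound 3 (0.18 log units; within the scatter), are all within the scatter. Compound 4 `Cc1cc(C#N)cc(C)c1Oc1ccnc(S(=O)(=O)CC(=O)Nc2cccc([N+](=O)[O-])c2)n1` carries 3-nitrophenyl in place of 4-chlorophenyl on an amide-type nitrogen. The step that bears most directly on this change, a 1.5-fold lower number from compound 2 to compound 3 (0.18 log units; within the scatter), also moved the aryl group on the same nitrogen and produced nothing beyond the scatter, and the two chloro additions did no more. Within the data shown here, no measured step involves a nitro group, so the expectation rests only on the insensitivity seen so far. Compound 4 is therefore expected to show no step beyond the scatter, a 1.2-fold higher number from compound 3 to compound 4 (0.08 log units; within the scatter), with an estimated value of 20000 nM in this assay, between 8000 nM and 55000 nM.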

Compound 4, half-maximal cytotoxic concentration: 23600 nM
For compound 4 the middle estimate is 1.2-fold (0.07 log units) below the measured one; the measured number falls inside the stated range.
By their numbers in this assay, from the lowest: compounds 3, 4, 2 and 1 (each within the scatter of the next).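

A nitro group, the only substituent here other than chloro on the aryl ring of the amide nitrogen, leaves the number in this assay within the scatter of every other compound in each comparison (a 1.4-fold higher number from compound 3 to compound 4 (0.15 log units; within the scatter)) (a 1.1-fold lower number from compound 2 to compound 4 (0.03 log units; within the scatter)) ((a 1.2-fold lower number from compound 1 to compound 4 (0.09 log units; within the scatter)). Exchanging chloro for nitro, which brings in two hydrogen-bond acceptors, therefore changes the reading no more than adding chloro did, and all the steps among these four compounds stay within the scatter. Nothing measured here offers an explanation for this insensitivity.

The compounds shown leave open whether a 4-nitrophenyl group on the same nitrogen would read the same. They also leave open whether an amine or a carboxylic acid on the aryl ring, or a longer chain in its place, would give a step beyond the scatter.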